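A few compounds are considered here, and "the series" means these few. Any claim that something is new, unique, unknown or untested is made for them only; others in the source may bear on it.

Measured in a functional assay on A549 cells (Homo sapiens) for cytotoxicity, read by XTT assay, with a stated time of 72 h; on this read-out higher numbers stand for weaker inhibition and lower numbers for stronger inhibition:
- Compound 1 `COc1cc(C(O)c2ccc3c(ccn3C)c2)cc(OC)c1OC`: > 10000 nM
- Compound 2 `CCn1ccc2cc(C(O)c3cc(OC)c(OC)c(OC)c3)ccc21`: > 10000 nM
- Compound 3 `COc1cc(C(OC(C)=O)c2ccc3c(ccn3C)c2)cc(OC)c1OC`: > 10000 nM

Compound 3 stands at the limit of > 10000 nM in this assay, at which 3 of the 3 values shown sit. Compound 4 `CCn1ccc2cc(C(OC(C)=O)c3cc(OC)c(OC)c(OC)c3)ccc21` differs from compound 3 by a single change: methyl in place of hydrogen on a saturated chain carbon bound to an aromatic nitrogen. In words, a methyl becomes an ethyl on the aromatic nitrogen. The same change appears as a step that the two limits leave unreadable from compound 1 to compound 2. The acetyl that compound 3 and compound 4 share appears as a step that the two limits leave unreadable from compound 1 to compound 3. Neither step has a readable size, so they give no sign of any gain in potency, and compound 4 is expected to stay at the limit. The estimated step is a step that the limit leaves unreadable from compound 3 to compound 4, with no shift expected beyond the scatter. For compound 4 the estimate is 12000 nM, with an expected range of 4000 nM to 30000 nM.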

Compound 4, half-maximal inhibitory concentration: > 10000 nM
Compound 4: only a limit was reported; the forecaster's own chance of this, stated with the estimate: 85%; the middle value does not contradict the limit.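

Compound 4 gives only a limit, so the steps to it from compound 2 and compound 3 cannot be read: the limit of > 10000 nM in this assay, at which 4 of the 4 values shown sit. The compounds shown leave open how potent any of them is, and whether the ethyl or the acetyl alters that potency at all.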